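Adding a Propyl Group: From Compound 3 to Compound 4

The source may report more compounds than this note shows. Statements on the series, on what has been measured and on what is new or still open speak of the compounds shown alone.

- Compound 1 `CCCCC1(CCCC)C[C@H](C(=O)OC)[C@@](C)(OC)OO1`: 98300 nM
- Compound 2 `CCCCC1(CCCC)C[C@H](C(=O)OC)[C@](CCCC)(OC)OO1`: 108000 nM
- Compound 3 `CCCC[C@@]1(OC)OOC(C)(C)C[C@@H]1C(=O)OC`: > 384000 nM

These three compounds were measured in an ADME assay on HMEC-1 cells (Homo sapiens) for cytotoxicity, read by MTT assay, with a stated time of 72 h; a higher number here means a weaker inhibitor, a lower number a stronger inhibitor. Compound 1 gives 98300 nM and compound 2 gives 108000 nM, and these two values lie within the usual scatter of each other.

Compound 3 gives only a limit, > 384000 nM, and not an exact number. It stands at the limit of > 384000 nM in this assay, at which 1 of the 3 values shown sits. On these data alone, its true position in this assay therefore remains unknown.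

Compound 4 `CCCC[C@@]1(C)C[C@H](C(=O)OC)[C@](CCCC)(OC)OO1` has not yet been measured. It differs from compound 3 by one change, propyl in place of hydrogen on a saturated chain carbon bound to a saturated ring carbon.

Among the measured compounds shown here, no step between measured compounds shows directly what such a change does, so any expectation here is uncertain. The closest guide is compound 2, which gives 108000 nM, and the estimate leans toward that level. A sizeable move toward a lower number, meaning a stronger inhibitor, is expected in this assay. The expected size of that move is an at least 2.4-fold lower number from compound 3 to compound 4 (0.38 log units; beyond the scatter).

For compound 4 the estimated value is 160000 nM, with an expected range of 80000 nM to 340000 nM.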

Compound 4, half-maximal inhibitory concentration: 167000 nM
Beside the measured number, compound 4's estimate is 1.0-fold (0.02 log units) below it; low and high end bracket the measured number.
By their numbers in this assay, from the lowest: compounds 1, 2 and 4 (each within the scatter of the next). At a limit, above all of these: compound 3.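

Among the compounds shown here, until this result, no two measured compounds differed in only one place, so nothing showed directly what a change at this position does in this assay. The new pair gives the first direct reading: propyl in place of hydrogen on a saturated chain carbon bound to a saturated ring carbon goes with an at least 2.2-fold lower number from compound 3 to compound 4 (0.36 log units; beyond the scatter). Compound 3 stands only at a limit, so the step gives a minimum size and its true size stays unknown: the limit of > 384000 nM in this assay, at which 1 of the 4 values shown sits.

Propyl is the only group that replaces hydrogen in this place among the compounds shown, and whether a shorter ethyl chain, a longer hexyl chain, an amine or a carboxylic acid in the same place would give a similar number remains open. On these data alone, it also remains open whether adding propyl would lower the number by a similar amount on a compound that differs elsewhere on the shared core, since this change is seen only once, in a single pair.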